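The compounds below may be only part of what the source reports. "The series", "measured", "known", "first", "only" and "open" are said of these compounds alone.

Measured so far in a functional assay on MDA-MB-231 cells (Homo sapiens) for antiproliferative activity, read by MTT assay; on this read-out higher numbers stand for weaker inhibition and lower numbers for stronger inhibition:

Compound 1, `CC/C=C\C/C=C\C/C=C\CCCCCCCC1(O)CC(=O)c2c(O)cc(OCOC)cc2O1`, gives 6790 nM.
Compound 2, `CCCC/C=C\CCCCCCCCCC1(O)CC(=O)c2c(O)cc(OCOC)cc2O1`, gives 42800 nM.
Compound 3, `CC/C=C\C/C=C\C/C=C\CCCCCCCc1cc(=O)c2c(O)c(C)c(OCOC)c(C)c2o1`, gives 16100 nM.

Compound 4, `CCCC/C=C\CCCCCCCCCc1cc(=O)c2c(O)c(C)c(OCOC)c(C)c2o1`, is not yet measured. It differs from compound 3 by a group of 8 heavy atoms (8 carbon; no ring) in place of a group of 10 heavy atoms (10 carbon; no ring), on a saturated chain carbon, seven bonds along the chain from an aromatic carbon. The same kind of change has already been seen once, from compound 1 to compound 2: a group of 8 heavy atoms (8 carbon; no ring) in place of a group of 10 heavy atoms (10 carbon; no ring), on a saturated chain carbon, seven bonds along the chain from a saturated ring carbon. There the result was a 6.3-fold higher number from compound 1 to compound 2 (0.80 log units; beyond the scatter), a weakening. The two places are not identical in words: in the first pair the chain starts from a saturated ring carbon, in the new pair from an aromatic carbon, and the difference between the two cores is not broken down here. Going by the values given here, since the one known step of this kind weakened inhibition, the step of a 4.3-fold higher number from compound 3 to compound 4 (0.64 log units; beyond the scatter) is expected to run the same way, with some caution because of a 6.3-fold higher number from compound 1 to compound 2 (0.80 log units; beyond the scatter) resting on a single pair. Compound 4 is therefore estimated at 70000 nM, within 25000 nM to 200000 nM.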

Compound 4, half-maximal inhibitory concentration: > 87000 nM
Compound 4 ended at the assay's limit; the forecaster's own chance of this, stated with the estimate: 30%; middle value at least 1.2-fold (0.09 log units) from the limit.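

In this assay the swap of the 10-carbon chain with 3 double bonds for oct-3-en-1-yl gave an at least 5.4-fold higher number from compound 3 to compound 4 (0.73 log units; beyond the scatter) on this core, a weakening, as on the core of compound 1. Compound 4 gives > 87000 nM as a limit of the assay, not as a number. The direction of the change therefore carries from one core to the other in these two pairs, but whether its size is the same cannot be said: the same change on two cores in this assay, a 6.3-fold higher number (0.80 log units; beyond the scatter) from compound 1 to compound 2 and an at least 5.4-fold higher number (0.73 log units; beyond the scatter) from compound 3 to compound 4; the limit leaves it open whether they differ.

The two chains differ in both length and number of double bonds, so the shown pairs do not separate these two features. From the compounds shown here alone, how a saturated decyl chain, or a chain ending in an amine or a carboxylic acid, would behave on either core stays open.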